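Phenyl in Place of Vinyl on the Thioether Arm

This account rests on a few compounds, and the source may have more. Where it says the series, first, only, none or still open, it means among the compounds named here.

Compound 1, `CCc1nnc(SCC(=O)c2ccc(C)cc2)n1N1C(=O)c2ccccc2C1=O`, gives > 200000 nM in a functional assay on A549 cells (Homo sapiens) for cytotoxicity, read by MTT assay, with a stated time of 48 h (on this read-out higher numbers stand for weaker inhibition and lower numbers for stronger inhibition), which is a limit of the assay rather than a number.
Compound 2, `C=CCSc1nnc(-c2cc(OC)c(OC)c(OC)c2)n1N1C(=O)c2ccccc2C1=O`, gives > 200000 nM in this assay, likewise a limit and not a number.

Compound 2 therefore stands at the limit of this assay, and the other measured compound stands at the same limit, as summed up in the limit of > 200000 nM in this assay, at which 2 of the 2 values shown sit. Among the compounds with values here, neither value is a number, so no difference between the two compounds can be read from them, and no measured step exists from which to judge the size of a structural change.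

Compound 3, `COc1cc(-c2nnc(SCc3ccccc3)n2N2C(=O)c3ccccc3C2=O)cc(OC)c1OC`, differs from compound 2 in one place: phenyl in place of vinyl on a saturated chain carbon bound to a sulfur. With both known values sitting at the limit, the expectation for compound 3 can rest only on that limit and on the smallness of the change. The expected step, a number no higher from compound 2 to compound 3 (the limit leaves the size open), is none beyond the scatter. Compound 3 is therefore expected to give 200000 nM, within a range of 40000 nM to 600000 nM, most likely reported again as a limit rather than as a number.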

Compound 3, half-maximal inhibitory concentration: > 200000 nM
Compound 3 was reported as a limit; the forecaster's own chance of this, stated with the estimate: 70%; the middle value sits exactly at the limit.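

No step can be read from compound 2 to compound 3, since each result is a limit and not a number, and all the compounds shown share one result: the limit of > 200000 nM in this assay, at which 3 of the 3 values shown sit.

What these compounds leave open is how strongly any of them acts on the cells, and whether putting phenyl in place of vinyl changes that at all.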